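The compounds below may be only part of what the source reports. "The series", "measured", "known", "first", "only" and "open" are said of these compounds alone.

Compound 2, `CC1=CC[C@H]2[C@H](CC[C@]2(C)O)C(C)(C)[C@@H]1CC[C@H]1[C@]2(C)CC[C@H](OCc3ccccc3)C(C)(C)O[C@H]2CC[C@@]1(C)O`, is one of two members of this series that have been tested in a functional assay on MDA-MB-231 cells (Homo sapiens) for antiproliferative activity, read by MTT assay, with a stated time of 72 h; on this read-out lower numbers stand for stronger inhibition and higher numbers for weaker inhibition. In this assay compound 2 gives 29100 nM. Its companion is compound 1, `CC1=CC[C@H]2[C@@H]1CC=C(C)[C@@H](CC[C@H]1[C@]3(C)CC[C@H](OC(=O)CCC(=O)O)C(C)(C)O[C@H]3CC[C@@]1(C)O)C2(C)C`, which in this assay gives 29600 nM. The two numbers lie within the scatter of each other, so neither compound can be set above the other on this read-out; both sit at the weak end of what the assay records. Going by the values given here, no step between the two has been worked out, and compound 1 has a different group on the same oxygen, so the present comparison rests on compound 2 alone.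

Compound 3, `CC1=CC[C@H]2[C@H](CC[C@]2(C)O)C(C)(C)[C@@H]1CC[C@H]1[C@]2(C)CC[C@H](OC(=O)c3ccccc3C(F)(F)F)C(C)(C)O[C@H]2CC[C@@]1(C)O`, is the next compound to be measured. It carries (2-(trifluoromethyl)phenyl)carbonyl in place of benzyl on an oxygen on a saturated carbon. Since compound 1 and compound 2 give numbers within the scatter of each other with different groups on that oxygen, no step beyond the scatter is expected from compound 2 to compound 3, and the step is estimated as a 1.2-fold lower number from compound 2 to compound 3 (0.07 log units; within the scatter). Compound 3 is accordingly expected to give about 25000 nM in this assay, within a range from 8000 nM to 80000 nM.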

Compound 3, half-maximal inhibitory concentration: 31500 nM
Compound 3: the middle estimate sits 1.3-fold (0.10 log units) below what was measured; the measured number falls inside the stated range.
By their numbers in this assay, from the lowest: compounds 2, 1 and 3 (each within the scatter of the next).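

In this assay, going by these compounds alone, putting (2-(trifluoromethyl)phenyl)carbonyl in place of benzyl on an oxygen on a saturated carbon gives a 1.1-fold higher number from compound 2 to compound 3 (0.03 log units; within the scatter), the first single change at this position that can be read as a step on the shared core. The entering group is larger than benzyl and brings a carbonyl, a hydrogen-bond acceptor and fluorine, while keeping the six-membered aromatic ring of carbon only, yet these differences together leave the number within the scatter. No measurement that could explain the size of this step is available.

As far as these compounds go, one step on this oxygen cannot show whether other groups there would move the number beyond the scatter, and a free hydroxyl, an amine or a plain alkyl chain without an aromatic ring remain open as replacements on the same core. From the compounds shown here alone, it also remains open whether the trifluoromethyl group and the carbonyl each leave the number unmoved when taken alone, or whether separate shifts cancel in the combined change.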